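Capping the amine of a long-chain amino alcohol

This account rests on a few compounds, and the source may have more. Where it says the series, first, only, none or still open, it means among the compounds named here.

Compound 1 `CCCCCCCCCCCCCCC(N)CO` is a long-chain amino alcohol tested in an ADME assay on cells (Splenocyte, Mus musculus, strain BALB/c) for cytotoxicity, read by MTT assay, tested at 10 ug/mL; a lower number here means a weaker effect, a higher number a stronger effect of the compound at the concentration tested. In that test compound 1 gives 20.2%. Compound 2 `CCCCCCCCCCCCCCC(COCc1ccccc1)NCC` carries a benzyl ether and an ethyl group on the nitrogen, and in this assay compound 2 gives 11.9%. Of the two numbers shown, compound 1's is the higher, yet the gap to compound 2 lies within the usual scatter of such measurements, so no real difference between the two can be claimed.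

Compound 3 `CCCCCCCCCCCCCCC(CO)NC(=O)CCCC(=O)OC` has not yet been measured. It differs from compound 1 in one place: (3-(methoxycarbonyl)propyl)carbonyl in place of hydrogen on an amine nitrogen. The amine nitrogen thus keeps its saturated chain carbon neighbour and gains the (3-(methoxycarbonyl)propyl)carbonyl group.

For the measured compounds named here, with only two measured compounds and no measured step between them, there is no firm guide to the size of this change. The expected change, a number 7.2 percentage points lower from compound 1 to compound 3 (within the scatter), is small, most likely a modest decrease or none beyond the scatter. For compound 3 the expected value in this assay is 13%, with a range from 2% to 28%.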

Compound 3, a percentage reported as activity, at one concentration (the size of the read-out at that concentration, not a potency): 18.9%
For compound 3 the middle estimate is 5.9 percentage points below the measured one; the measured number falls inside the stated range.
By their numbers in this assay, from the lowest: compounds 2, 3 and 1 (each within the scatter of the next).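

For the compounds shown here, this is the first step at the amine nitrogen that can be read on its own: in this assay, putting (3-(methoxycarbonyl)propyl)carbonyl in place of hydrogen gives a number 1.3 percentage points lower from compound 1 to compound 3 (within the scatter) and so leaves no difference that can be told from the scatter. At this one concentration, the position therefore accepts a ring-free group carrying an ester and a new amide carbonyl, with the read-out of compound 3 indistinguishable from that of compound 1. No measurement shown offers a reason for this outcome.

Going by these compounds, compound 2 differs from compound 1 in more than one place, so it cannot show whether its ethyl group on the nitrogen or its benzyl ether would matter alone, and the effect of each remains unknown. On these data alone, it also remains open whether the same tolerance would hold for a simple acetyl group on the nitrogen, a longer chain between the two carbonyl groups, or a carboxylic acid in place of the methyl ester.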